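A few compounds are considered here, and "the series" means these few. Any claim that something is new, unique, unknown or untested is made for them only; others in the source may bear on it.

Compound 1 `N#CCCSC(=S)NCc1cccnc1` gives 2840 nM
Compound 2 `FC(F)(F)c1ccc(-c2nnc(CCSC(=S)NCc3cccnc3)o2)cc1` gives 2400 nM
Compound 3 `O=[N+]([O-])c1ccc(-c2nnc(CCSC(=S)NCc3cccnc3)o2)cc1` gives 1540 nM

In a functional assay on SK-BR-3 cells (Homo sapiens) for cytotoxicity, read by resazurin assay, with a stated time of 72 h (a lower number here means a stronger inhibitor, a higher number a weaker inhibitor), compound 3 stands at 1540 nM and lies within the scatter of both other compounds, so these three cannot be ranked. Compound 4 `S=C(NCc1cccnc1)SCCc1nnc(-c2cccs2)o1` carries thiophen-2-yl in place of 4-nitrophenyl on an aromatic carbon. Going by the values given here, the one measured step that bears on this, a 1.6-fold lower number from compound 2 to compound 3 (0.19 log units; within the scatter), altered only a group on that aromatic ring and stayed within the scatter. Among the compounds with values here, no measured compound carries thiophen-2-yl, so this swap itself is untested. Compound 1, which has no 4-nitrophenyl group, gives 2840 nM and also lies within the scatter of compound 3. In this assay no step beyond the scatter is therefore expected, and the estimated change is a 1.3-fold higher number from compound 3 to compound 4 (0.11 log units; within the scatter) in size. For compound 4 the estimated value is 2000 nM, with an expected range from 900 nM to 4500 nM.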

Compound 4, half-maximal inhibitory concentration: 1070 nM
Estimate against measurement, compound 4: 1.9-fold (0.27 log units) above; low and high end bracket the measured number.
By their numbers in this assay, from the lowest: compounds 4, 3, 2 and 1 (each within the scatter of the next, the first and the last beyond it).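

In this assay, going by these compounds alone, the whole aryl ring at this position is exchanged for the first time, not just a group on it, and thiophen-2-yl in place of 4-nitrophenyl gives a 1.4-fold lower number from compound 3 to compound 4 (0.16 log units; within the scatter). So this aromatic carbon of the shared core accepts a five-membered ring with sulfur, of 5 heavy atoms instead of 9, with no step beyond the scatter. Nothing measured here offers an explanation for this result. Still open, going by these compounds, is whether a furan-2-yl ring, a plain methyl, an amine or a carboxylic acid at this carbon would move the number beyond the scatter.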